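Swapping the aryl acid end on a cyclopentyl ketone

The source may report more compounds than this note shows. Statements on the series, on what has been measured and on what is new or still open speak of the compounds shown alone.

Compound 2 `COc1ccc(C(=O)O)cc1OCCCCOc1ccc(C(=O)CC2CCCC2)c(O)c1C` is measured in an assay on HEK293 cells for positive allosteric modulation of metabotropic glutamate receptor 3 (Rattus norvegicus), read by thallium flux, with a stated time of 2.5 min (on this read-out higher numbers stand for an effect only at larger amounts of compound and lower numbers for an effect already at smaller amounts), where compound 2 gives 1020 nM. Among the three measured compounds this is the highest number: compound 3 `COc1ccc(C(=O)O)cc1OCCCCOc1ccc(C(=O)CC(C)C)c(O)c1C` gives 737 nM, and compound 1 `CCCC(=O)c1ccc(OCCCCOc2ccc(F)c(C(=O)O)c2)c(C)c1O` gives 438 nM, so compound 2 sits closest to compound 3 and furthest from compound 1. Going by the values given here, the only single change measured, a 1.4-fold lower number from compound 2 to compound 3 (0.14 log units; within the scatter), concerns the ketone side and not the part altered here. Compound 4 `Cc1c(OCCCCOc2ccc(F)c(C(=O)O)c2)ccc(C(=O)CC2CCCC2)c1O` differs from compound 2 at the other end of the chain: 3-carboxy-4-fluorophenyl in place of 5-carboxy-2-methoxyphenyl on an oxygen on a saturated carbon. Among the compounds with values here, no measured pair isolates this aryl swap; compound 1 and compound 3 carry the two different aryl acids but also differ at the ketone, and their values differ only moderately. Compound 4 is therefore expected to land somewhat lower than compound 2, by a step of about a 1.6-fold lower number from compound 2 to compound 4 (0.22 log units; within the scatter), with real uncertainty. The estimate for compound 4 in this assay is 620 nM, within a range from 250 nM to 1500 nM.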

Compound 4, half-maximal effective concentration: 2490 nM
Compound 4: the middle estimate sits 4.0-fold (0.60 log units) below what was measured, outside the stated range (above it).
By their numbers in this assay, from the lowest: compounds 1, 3 and 2 (each within the scatter of the next, the first and the last beyond it); then compound 4.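

In this assay, going by these compounds alone, the aryl acid end proves to matter on its own: 3-carboxy-4-fluorophenyl in place of 5-carboxy-2-methoxyphenyl gives a 2.4-fold higher number from compound 2 to compound 4 (0.39 log units; beyond the scatter) and is the first clean reading of this swap. The ketone side also counts with the fluorinated end in place, where cyclopentyl in place of ethyl gives a 5.7-fold higher number from compound 1 to compound 4 (0.75 log units; beyond the scatter) while the earlier ketone change on the methoxy end, a different pair of groups, gives a 1.4-fold lower number from compound 2 to compound 3 (0.14 log units; within the scatter) and stays within the scatter. Nothing available explains either step.

Still open, on these data alone, is which part of the aryl swap carries the step, the fluorine, the methoxy group or the place of the carboxy group. Also open, as far as these compounds go, is how a plain 3-carboxyphenyl end, or a tetrazole in place of the carboxylic acid, would read on the cyclopentyl ketone.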